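Swapping the phenol of compound 1 for a trimethoxyphenyl

A few compounds are considered here, and "the series" means these few. Any claim that something is new, unique, unknown or untested is made for them only; others in the source may bear on it.

Measured compounds:
Compound 1, `COc1cc(C=C(C(=O)/C=C/c2cccc(OC)c2OC)C(=O)/C=C/c2cccc(OC)c2OC)ccc1O`: 280 nM
Compound 2, `COc1cccc(/C=C/C(=O)C(=Cc2cc(OC)c(OC)c(OC)c2)C(=O)/C=C/c2cccc(OC)c2OC)c1OC`: 400 nM
Compound 3, `COc1cc(OC)c(C=C(C(=O)/C=C/c2cccc(OC)c2OC)C(=O)/C=C/c2cccc(OC)c2OC)c(OC)c1`: 630 nM

All three were tested in a functional assay on CNE-2 cells (Homo sapiens) for antiproliferative activity, read by sulforhodamine B assay, with a stated time of 48 h; a higher number here means a weaker inhibitor, a lower number a stronger inhibitor. Compound 1 gives the lowest number of the three, though its distance to compound 2 is small: the step of a 1.4-fold higher number from compound 1 to compound 2 (0.15 log units; within the scatter) lies within the scatter, so the two cannot be ordered. The step of a 2.3-fold higher number from compound 1 to compound 3 (0.35 log units; beyond the scatter) lies beyond the scatter, a modest rise. Between the two trimethoxy compounds the step of a 1.6-fold higher number from compound 2 to compound 3 (0.20 log units; within the scatter) is again within the scatter.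

The unmeasured compound 4, `COc1cccc(/C=C/C(=O)C(=Cc2ccc(OC)c(OC)c2OC)C(=O)/C=C/c2cccc(OC)c2OC)c1OC`, differs from compound 1 in one place: 2,3,4-trimethoxyphenyl in place of 4-hydroxy-3-methoxyphenyl on a double-bonded chain carbon bound to a double-bonded chain carbon. The two measured steps that bear on it, a 1.4-fold higher number from compound 1 to compound 2 (0.15 log units; within the scatter) and a 2.3-fold higher number from compound 1 to compound 3 (0.35 log units; beyond the scatter), both put a trimethoxyphenyl in place of 4-hydroxy-3-methoxyphenyl at the same position and both raise the number, one within and one beyond the scatter. A third arrangement of the three methoxy groups is therefore expected to behave much the same, with a small rise that may or may not exceed the scatter. Compound 4 is expected to give about 450 nM, with a likely range from 250 nM to 800 nM. The expected step of a 1.6-fold higher number from compound 1 to compound 4 (0.21 log units; within the scatter) is estimated to be of the same size as those seen for compound 2 and compound 3.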

Compound 4, half-maximal inhibitory concentration: 410 nM
Compound 4: the middle estimate sits 1.1-fold (0.04 log units) above what was measured, within the range that was stated.
By their numbers in this assay, from the lowest: compounds 1, 2, 4 and 3 (each within the scatter of the next, the first and the last beyond it).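

With a 1.5-fold higher number from compound 1 to compound 4 (0.17 log units; within the scatter) in this assay, a second trimethoxyphenyl arrangement stays within the scatter of compound 1, so at this place the 4-hydroxy-3-methoxyphenyl group with its 1 hydrogen-bond donor can give way to a group with 0 donors without a step that can be read. The new compound also links the other two trimethoxyphenyl compounds: a 1.0-fold higher number from compound 2 to compound 4 (0.01 log units; within the scatter) and a 1.5-fold lower number from compound 3 to compound 4 (0.19 log units; within the scatter) both lie within the scatter, so 2,3,4-trimethoxyphenyl cannot be told apart from either 3,4,5-trimethoxyphenyl or 2,4,6-trimethoxyphenyl, and the step from compound 1 to compound 3 remains the only one beyond the scatter. Nothing given here accounts for these numbers, and no cause can be assigned to them.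

The compounds shown leave open how this place would respond to a phenyl ring carrying an amine or a carboxylic acid, or to longer chains in place of the methoxy groups. They also leave open whether a phenol with a different arrangement of its groups would sit any closer to compound 1 than the trimethoxyphenyl compounds do.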